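Extending the aromatic substituent from trifluoromethyl to 4-chlorophenyl

The source may report more compounds than this note shows. Statements on the series, on what has been measured and on what is new or still open speak of the compounds shown alone.

Going by the values given here, in an assay on isolated protein for inhibition of alpha-ketoglutarate-dependent dioxygenase alkB homolog 3 (Homo sapiens), read by polymerase chain reaction, with a stated time of 1 h (on this read-out lower numbers stand for stronger inhibition and higher numbers for weaker inhibition), compound 2 `Cc1[nH]n(-c2nc3cc(C(F)(F)F)ccc3[nH]2)c(=O)c1Cc1ccccc1` gives 610 nM, the lowest of the two numbers so far; compound 1 `Cc1[nH]n(-c2nc3cc(Cl)ccc3[nH]2)c(=O)c1Cc1ccccc1` gives 4500 nM. Among the compounds with values here, the one step on record, a 7.4-fold lower number from compound 1 to compound 2 (0.87 log units; beyond the scatter), shows that a change at this carbon can move the read-out beyond the scatter. Compound 3 `Cc1[nH]n(-c2nc3cc(-c4ccc(Cl)cc4)ccc3[nH]2)c(=O)c1Cc1ccccc1` carries 4-chlorophenyl in place of trifluoromethyl on an aromatic carbon. Within the data shown here, because the only related step is a 7.4-fold lower number from compound 1 to compound 2 (0.87 log units; beyond the scatter), and not a direct precedent, the expected change a 1.5-fold lower number from compound 2 to compound 3 (0.18 log units; within the scatter) is uncertain in direction. Compound 3 is estimated at 400 nM, within 80 nM to 2500 nM.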

Compound 3, half-maximal inhibitory concentration: 1500 nM
For compound 3 the middle estimate is 3.8-fold (0.57 log units) below the measured one; the range from low to high includes it.
By their numbers in this assay, from the lowest: compound 2; then compound 3; then compound 1.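

Putting 4-chlorophenyl in place of trifluoromethyl gives a 2.5-fold higher number from compound 2 to compound 3 (0.39 log units; beyond the scatter), while putting it in place of chloro gives a 3.0-fold lower number from compound 1 to compound 3 (0.48 log units; beyond the scatter). A six-membered aromatic ring at this carbon is therefore compatible with inhibition, but the largest group, with 7 heavy atoms, does not give the lowest number, so the number does not simply fall as the group grows. No evidence is available to explain this order. On these data alone, whether an amine, a carboxylic acid or an unsubstituted phenyl at this carbon would give a lower number remains open, as do changes elsewhere on the shared core.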